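Trifluoromethyl to Methyl on the Ketone of Compound 3

The compounds below may be only part of what the source reports. "The series", "measured", "known", "first", "only" and "open" are said of these compounds alone.

Compound 1: `O=C(CCCCCc1ccccc1)c1nc2ncccc2s1`, > 10000 nM
Compound 2: `O=C(CCCCCCc1ccccc1)c1ncc(-c2ccco2)s1`, > 10000 nM
Compound 3: `O=C(CCCCCCc1ccccc1)c1ncc(C(=O)C(F)(F)F)o1`, 1820 nM

Within the data shown here, in an assay on HEK-293T cells for inhibition of diacylglycerol lipase-alpha (Homo sapiens), read by colorimetric assay (a higher number here means a weaker inhibitor, a lower number a stronger inhibitor), compound 3 gives 1820 nM, the only number among the three. For compound 1 the result of > 10000 nM is a limit of this assay, not a number. For compound 2 the result of > 10000 nM is likewise a limit (the limit of > 10000 nM in this assay, at which 2 of the 3 values shown sit). Compound 4, `CC(=O)c1cnc(C(=O)CCCCCCc2ccccc2)o1`, carries methyl in place of trifluoromethyl on a carbonyl carbon. Among the measured compounds shown here, no measured pair shows this change, so the direction is estimated from compound 3 alone. Compound 4 is expected to be weaker, with a step of a 4.4-fold higher number from compound 3 to compound 4 (0.64 log units; beyond the scatter) beyond the usual scatter. Compound 4 is estimated at 8000 nM, between 2500 nM and 30000 nM, and a limit is quite possible.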

Compound 4, half-maximal inhibitory concentration: > 10000 nM
Compound 4 ended at the assay's limit (the forecaster's own chance of this, stated with the estimate: 45%); at least 1.2-fold (0.09 log units) between middle value and limit.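

In this assay compound 4 gives > 10000 nM, which is a limit of the assay and not a number. Methyl in place of trifluoromethyl on a carbonyl carbon gives an at least 5.4-fold higher number from compound 3 to compound 4 (0.73 log units; beyond the scatter), the first step shown between compounds that differ in one place, and it ties the measurable value of compound 3 to the trifluoromethyl group at this place. Compound 3 remains the only compound with a number: the limit of > 10000 nM in this assay, at which 3 of the 4 values shown sit.

As far as these compounds go, the full size of the step stays open, as only its minimum can be read. Also open, from the compounds shown here alone, is whether difluoromethyl or ethyl on this carbonyl carbon would give a number rather than a limit.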